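The source may report more compounds than this note shows. Statements on the series, on what has been measured and on what is new or still open speak of the compounds shown alone.

Values measured in a functional assay on HeLa S3 cells (Homo sapiens) for antiproliferative activity, read by XTT assay, with a stated time of 72 h; on this read-out higher numbers stand for weaker inhibition and lower numbers for stronger inhibition:
- Compound 1 `CN(C)c1ncnc2c1c(-c1ccoc1)cn2[C@@H]1O[C@H](CO)[C@@H](O)[C@H]1O` gives 9060 nM as a number
- Compound 2 `Nc1nc(N)c2c(-c3ccsc3)cn([C@@H]3O[C@H](CO)[C@@H](O)[C@H]3O)c2n1` gives > 20000 nM as a limit
- Compound 3 `Nc1nc2c(c(-c3ccco3)cn2[C@@H]2O[C@H](CO)[C@@H](O)[C@H]2O)c(=O)[nH]1` gives > 20000 nM as a limit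

Compound 3 has no numerical value in this assay: compound 3 stands at > 20000 nM as a limit and not as a number. It thus belongs with the group described as the limit of > 20000 nM in this assay, at which 2 of the 3 values shown sit, and shared with compound 2. Only compound 1 reads as a number, and it differs from compound 3 in more than one place.

The next compound, compound 4 `Nc1nc2c(c(-c3ccccc3)cn2[C@@H]2O[C@H](CO)[C@@H](O)[C@H]2O)c(=O)[nH]1`, carries phenyl in place of furan-2-yl on an aromatic carbon. Going by the values given here, no measured pair isolates this change. The expectation therefore rests on compound 3 at > 20000 nM as a limit. No change beyond the usual scatter is expected, and the estimated move is a step that the limit leaves unreadable from compound 3 to compound 4 in size. Another report of a limit is the likeliest outcome. For compound 4 the estimated value is 25000 nM, with an expected range from 9000 nM to 70000 nM as its ends.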

Compound 4, half-maximal inhibitory concentration: > 20000 nM
Compound 4 was reported as a limit; the forecaster's own chance of this, stated with the estimate: 85%; the middle value does not contradict the limit.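

In this assay compound 4 gives > 20000 nM, which is a limit and not a number. Going by these compounds alone, compound 3 stands at the same limit, so no step between compound 3 and compound 4 can be read. The compounds shown leave open whether phenyl and furan-2-yl differ in this assay at all.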